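Ethoxy for methoxy in sulfonylurea aortic relaxants

The source may hold more compounds than are shown below. What is called first, only, known or untested is meant among the compounds shown, and "the series" means these compounds.

Measured so far:
compound 1 `COc1ccc(Cl)cc1C(C)NC(=O)NS(=O)(=O)c1ccc(Cl)cc1` — > 300000 nM
compound 2 `COc1ccc(Cl)cc1C(C)NC(=O)N(C)S(=O)(=O)c1ccc(C)cc1` — 13800 nM
compound 3 `CCOc1ccc(Cl)cc1C(C)NC(=O)NS(=O)(=O)c1ccc(Cl)cc1` — 281000 nM

In a functional assay on thoracic aorta (Rattus norvegicus, strain Wistar), with a stated time of 15 min (on this read-out higher numbers stand for an effect only at larger amounts of compound and lower numbers for an effect already at smaller amounts), compound 1 gives only a limit, > 300000 nM. Compound 3 gives 281000 nM in this assay, and the change methyl in place of hydrogen on a saturated chain carbon bound to an oxygen on an aromatic ring produced the step of an at least 1.0-fold lower number from compound 1 to compound 3 (0.02 log units; that floor lies within the scatter). That this step is stated as open-ended rests on (the limit of > 300000 nM in this assay, at which 1 of the 3 values shown sits), which concerns compound 1. Compound 2 gives 13800 nM in this assay; how the cores of compound 1 and compound 2 differ is not broken down here.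

Compound 4 `CCOc1ccc(Cl)cc1C(C)NC(=O)N(C)S(=O)(=O)c1ccc(C)cc1` is not yet measured. It carries the same change as compound 3, (methyl in place of hydrogen on a saturated chain carbon bound to an oxygen on an aromatic ring), set on the core of compound 2. Since the earlier step of an at least 1.0-fold lower number from compound 1 to compound 3 (0.02 log units; that floor lies within the scatter) stayed within the scatter, a step of similar size is expected from compound 2, a 1.3-fold lower number from compound 2 to compound 4 (0.10 log units; within the scatter). Compound 4 is therefore estimated at 11000 nM in this assay, between 4000 nM and 30000 nM.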

Compound 4, half-maximal effective concentration: 12200 nM
Estimate against measurement, compound 4: 1.1-fold (0.04 log units) below; low and high end bracket the measured number.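

In this assay the change from methoxy to ethoxy gives a 1.1-fold lower number from compound 2 to compound 4 (0.05 log units; within the scatter) so on this core the two compounds cannot be told apart. Neither core shows a step beyond the scatter, but this does not establish that the change acts alike on both: the same change on two cores in this assay, an at least 1.0-fold lower number (0.02 log units; that floor lies within the scatter) from compound 1 to compound 3 and a 1.1-fold lower number (0.05 log units; within the scatter) from compound 2 to compound 4; the limit leaves it open whether they differ. The earlier step has an open end, and this note covers only these two cores: the limit of > 300000 nM in this assay, at which 1 of the 4 values shown sits.

Only methoxy and ethoxy are shown at this oxygen, so it remains open whether a longer chain such as propyl or butyl would shift the number beyond the scatter. From the compounds shown here alone, a free hydroxyl group at the same place also remains open.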